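This account rests on a few compounds, and the source may have more. Where it says the series, first, only, none or still open, it means among the compounds named here.

Measured so far:
- compound 1, `COc1cc2cc(Oc3ccc(NC(=O)Nc4cccc(C(F)(F)F)c4)cc3)c(C)nc2cc1OC`: in a functional assay on SF-295 cells (Homo sapiens) for inhibition, read by sulforhodamine B assay, with a stated time of 48 h (a higher number here means that more compound is tolerated, a lower number that less compound is tolerated), compound 1 gives 27200 nM
- compound 2, `COc1cc2cc(Oc3ccc(NC(=O)Nc4ccc(Cl)c(C(F)(F)F)c4)cc3)c(C)nc2cc1OC`: in this assay compound 2 gives 22200 nM

Going by the values given here, compound 2 stands close to the only other compound with a number: the step of a 1.2-fold lower number from compound 1 to compound 2 (0.09 log units; within the scatter) is within the scatter, so the two values cannot be told apart, and both describe compounds that the cells tolerate in large amounts.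

Compound 3, `COc1cc2cc(Oc3ccc(NC(=O)Nc4ccc(Cl)c(Cl)c4)cc3)c(C)nc2cc1OC`, differs from compound 2 by chloro in place of trifluoromethyl on an aromatic carbon. Among the compounds with values here, the one measured step that touches this ring, a 1.2-fold lower number from compound 1 to compound 2 (0.09 log units; within the scatter), added a chloro group and moved the number by an amount within the scatter. Within the data shown here, no measured pair swaps a trifluoromethyl for a chloro, so the expectation for that swap rests only on the observation that a change on this ring, in compound 1 to compound 2, left the number essentially unchanged. The step of a 1.0-fold lower number from compound 2 to compound 3 (0.00 log units; within the scatter) is therefore expected to stay within the scatter, with no clear direction. For compound 3 in this assay the estimate is 22000 nM, with a range from 10000 nM to 48000 nM.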

Compound 3, concentration lethal to 50% of the cells: 67700 nM
Compound 3: middle estimate off by 3.1-fold (0.49 log units), on the low side, outside the stated range (above it).
By their numbers in this assay, from the lowest: compounds 2 and 1 (each within the scatter of the next); then compound 3.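

In this assay, the group on this aromatic carbon turns out to matter: chloro in place of trifluoromethyl, ortho to a chloro group, gives a 3.0-fold higher number from compound 2 to compound 3 (0.48 log units; beyond the scatter), a modest step but beyond the scatter, so the cells tolerate more of compound 3. The earlier step, a 1.2-fold lower number from compound 1 to compound 2 (0.09 log units; within the scatter), changed a different carbon of this ring and could not be told from scatter, so it gave no sign that the ring responds to substitution at all. The step of a 2.5-fold higher number from compound 1 to compound 3 (0.40 log units; beyond the scatter), with 3,4-dichlorophenyl in place of 3-(trifluoromethyl)phenyl, points the same way and leaves compound 3 with the highest number of the three, though no measurement here explains why this swap moves the number.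

The compounds shown leave open whether the rise belongs to chloro itself or to the loss of trifluoromethyl, which a hydrogen, a methyl or a bromo on the same carbon would help to separate. They also leave open how a methoxy or an amine at this position would behave, and whether the 4-chloro group is needed for the rise.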